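An alkynyl chain rearranged at a limit

This account rests on a few compounds, and the source may have more. Where it says the series, first, only, none or still open, it means among the compounds named here.

Measured in an ADME assay on L02 cells (Homo sapiens) for antiproliferative activity, read by MTT assay, with a stated time of 48 h; on this read-out higher numbers stand for weaker inhibition and lower numbers for stronger inhibition:
Compound 1 `CCn1c(C(=O)NCCN(C)C)ccc1C(CC)(CC)c1ccc(OCCC(O)(CC)CC)c(C)c1`: 990 nM
Compound 2 `C#CC(C)OC(=O)c1ccc(C(CC)(CC)c2ccc(OCCC(O)(CC)CC)c(C)c2)n1CC`: > 50000 nM (a limit)

Compound 2 stands at the limit of > 50000 nM in this assay, at which 1 of the 2 values shown sits. It therefore has a limit of the assay and not a number. Compound 3 `C#CCCOC(=O)c1ccc(C(CC)(CC)c2ccc(OCCC(O)(CC)CC)c(C)c2)n1CC` has the same atoms, joined differently: but-3-yn-1-yl in place of 1-methylprop-2-yn-1-yl on an oxygen next to a carbonyl group.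

Among the compounds with values here, only one measured step bears on this change, and only indirectly. The step of an at least 50-fold higher number from compound 1 to compound 2 (1.70 log units; beyond the scatter) is large, but it replaces (2-(dimethylamino)ethyl)amino on a carbonyl carbon with (1-methylprop-2-yn-1-yl)oxy. Compound 3 retains the oxygen on that carbonyl and alters only the chain beyond it. No step beyond the scatter is therefore expected in this assay, and no direction can be foreseen. The expected step is a number no higher from compound 2 to compound 3 (the limit leaves the size open). Compound 3 is estimated at 50000 nM, within an expected range of 20000 nM to 80000 nM, and it may well be reported only as a limit.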

Compound 3, half-maximal inhibitory concentration: > 50000 nM
Compound 3: no number, only a limit; the forecaster's own chance of this, stated with the estimate: 75%; the middle value lies on the limit itself.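

In this assay compound 3 gives > 50000 nM as a limit and not a number, so but-3-yn-1-yl in place of 1-methylprop-2-yn-1-yl on the oxygen still yields no measurable value. With (but-3-yn-1-yl)oxy in place of (2-(dimethylamino)ethyl)amino on a carbonyl carbon there is an at least 50-fold higher number from compound 1 to compound 3 (1.70 log units; beyond the scatter) and so the large step seen with the first alkynyl chain recurs with the second. The step between compound 2 and compound 3 cannot be read, as both values are limits: the limit of > 50000 nM in this assay, at which 2 of the 3 values shown sit.

Going by these compounds, it remains open whether a methyl group on that oxygen, or a free carboxylic acid at the carbonyl, would give a number. Also open, on these data alone, is how much of the step depends on the dimethylamino amine rather than the amide itself, which a simple ethyl amide could help to separate.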